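Swapping the aryl substituent in a ubiquitin hydrolase inhibitor series

This account rests on a few compounds, and the source may have more. Where it says the series, first, only, none or still open, it means among the compounds named here.

Measured compounds:
- compound 1, `Cn1nc2c(=O)n(CC3(O)CCN(Cc4ccc(C5=CCCC5)cc4Cl)CC3)cnc2c1-c1ccc(CN)cc1`: 76.9 nM
- compound 2, `Cn1nc2c(=O)n(CC3(O)CCN(Cc4ccc(-c5ccsc5Cl)cc4Cl)CC3)cnc2c1-c1ccc(CN)cc1`: 453 nM

Both compounds were tested in an assay on isolated protein for inhibition of ubiquitin carboxyl-terminal hydrolase 7 (Homo sapiens), with stated times of 30 min and 2 h; a lower number here means a stronger inhibitor, a higher number a weaker inhibitor. Compound 2 gives the highest number of the two; its nearest neighbour is compound 1, and the step of a 5.9-fold higher number from compound 1 to compound 2 (0.77 log units; beyond the scatter) lies beyond the scatter, so compound 2 is the weaker inhibitor of the pair.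

Compound 3, `Cn1nc2c(=O)n(CC3(O)CCN(Cc4ccc(-c5ccc(C(=O)O)o5)cc4Cl)CC3)cnc2c1-c1ccc(CN)cc1`, has not yet been measured. It differs from compound 2 at one place: 5-carboxyfuran-2-yl in place of 2-chlorothiophen-3-yl on an aromatic carbon. Among the measured compounds shown here, no measured step bears directly on this change, since the only step in hand, a 5.9-fold higher number from compound 1 to compound 2 (0.77 log units; beyond the scatter), exchanges a cyclopent-1-en-1-yl for a 2-chlorothiophen-3-yl group and tells nothing about a 5-carboxyfuran-2-yl at the same place. That step does show that this position can move the number by a modest amount. With no closer guide, the expected step of a 1.3-fold higher number from compound 2 to compound 3 (0.12 log units; within the scatter) is small and of uncertain direction, with a wide range. Compound 3 is therefore estimated at 600 nM, between 150 nM and 2500 nM, in this assay.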

Compound 3, half-maximal inhibitory concentration: 753 nM
Compound 3: the middle estimate sits 1.3-fold (0.10 log units) below what was measured, and the stated range covers the measured number.
By their numbers in this assay, from the lowest: compound 1; then compounds 2 and 3 (each within the scatter of the next).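

In this assay, replacing the 2-chlorothiophen-3-yl group with the 5-carboxyfuran-2-yl group gives a 1.7-fold higher number from compound 2 to compound 3 (0.22 log units; within the scatter), so these two five-membered aromatic rings cannot be told apart at this position, even though only the entering group carries a hydrogen-bond donor and only the leaving group carries a chlorine. Set against the cyclopent-1-en-1-yl group, the 5-carboxyfuran-2-yl group gives a 9.8-fold higher number from compound 1 to compound 3 (0.99 log units; beyond the scatter), which shows that the gap first seen with compound 2 is not particular to the chlorothiophene: both aromatic rings stand apart from compound 1, the strongest inhibitor of the three. Nothing in hand explains this gap or the closeness of compound 2 and compound 3.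

The compounds shown leave open whether the gap to compound 1 follows from the aromatic ring itself or from the substituents on it, a question that an unsubstituted furan, a plain phenyl ring or a saturated cyclopentyl group at this place would address. They also leave open what the carboxylic acid contributes to the furan, which its methyl ester or primary amide would test.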